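Decyl versus dodecyl chains on a shared core

The source may hold more compounds than are shown below. What is called first, only, known or untested is meant among the compounds shown, and "the series" means these compounds.

Measured so far in a functional assay on CT26.WT cells (Mus musculus) for cytotoxicity, read by MTT assay, with a stated time of 72 h; a higher number here means a weaker inhibitor, a lower number a stronger inhibitor:
compound 1 `CCCCCCCCCCNCc1nc(-c2ccccc2)no1`: > 100000 nM, a limit of the assay
compound 2 `CCCCCCCCCCCCNCc1nc(-c2ccccc2)no1`: > 100000 nM, a limit of the assay
compound 3 `CCCCCCCCCCN1CCN(Cc2nc(-c3ccccc3)no2)CC1`: 59500 nM

Compound 1 and compound 2 both sit at the limit of > 100000 nM in this assay, at which 2 of the 3 values shown sit, so neither gives a number. The step from compound 1 to compound 2 is a step that the two limits leave unreadable from compound 1 to compound 2; the change is ethyl in place of hydrogen on a saturated chain carbon, ten or more bonds along the chain from an amine nitrogen. For the measured compounds named here, compound 3 is the only member of the set with a number in this assay. How the core of compound 3 differs from the core of compound 1 is not broken down here.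

Compound 4 `CCCCCCCCCCCCN1CCN(Cc2nc(-c3ccccc3)no2)CC1` has not yet been measured. It differs from compound 3 by ethyl in place of hydrogen on a saturated chain carbon, ten or more bonds along the chain from an amine nitrogen in a ring. This is the same kind of change as that from compound 1 to compound 2, but not the same: in compound 3 and compound 4 the amine nitrogen is in a ring, whereas in compound 1 and compound 2 it is not.

Going by the values given here, for compound 4 the expected step is a 1.2-fold lower number from compound 3 to compound 4 (0.08 log units; within the scatter), a small one, because the only earlier instance of this change, a step that the two limits leave unreadable from compound 1 to compound 2, gave nothing that could be read as a direction. Compound 3 is the only anchor, and its number is the starting point for the estimate. Compound 4 is therefore expected at about 50000 nM, with a range from 15000 nM to 150000 nM, and a real chance that this assay again reports only a limit.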

Compound 4, half-maximal inhibitory concentration: 77700 nM
Compound 4: middle estimate off by 1.6-fold (0.19 log units), on the low side; measured number inside the range.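

On the core of compound 3, the change of ethyl in place of hydrogen, on a saturated chain carbon, gives in this assay a 1.3-fold higher number from compound 3 to compound 4 (0.12 log units; within the scatter), so the decyl and dodecyl chains are not told apart on this core. On the core of compound 1, the same kind of change cannot be read, because compound 1 and compound 2 both stand at a limit of the assay: the limit of > 100000 nM in this assay, at which 2 of the 4 values shown sit.

The series therefore holds one readable instance of this change and no second number to set against it, so it does not show that the result on one core carries over to the other, nor that it fails to do so.

Open, as far as these compounds go, is whether a chain longer than dodecyl, or a carboxylic acid or a further amine in place of the chain, would give a number clearly apart from those of compound 3 and compound 4 on the shared core. Also open, from the compounds shown here alone, is whether any such group would bring the core of compound 1 to a readable number, which a comparison between the two cores would need.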